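The source may report more compounds than this note shows. Statements on the series, on what has been measured and on what is new or still open speak of the compounds shown alone.

In a functional assay on A-431 cells (Homo sapiens) for antiproliferative activity, read by MTT assay, with a stated time of 72 h (a lower number here means a stronger inhibitor, a higher number a weaker inhibitor), compound 1 `COc1cc2ncnc(Nc3ccc(F)c(Cl)c3)c2cc1OCCCCC(=O)Nc1ccc(S(N)(=O)=O)cc1` gives 5020 nM, and compound 2 `COc1ccc(Nc2ncnc3cc(OC)c(OCCCCC(=O)Nc4ccc(S(N)(=O)=O)cc4)cc23)cc1` gives 14700 nM; the step of a 2.9-fold higher number from compound 1 to compound 2 (0.47 log units; beyond the scatter) shows that swapping the aryl group on the ring nitrogen shifts the result. Compound 2 therefore holds the highest number of the two. Compound 3 `COc1ccccc1Nc1ncnc2cc(OC)c(OCCCCC(=O)Nc3ccc(S(N)(=O)=O)cc3)cc12` differs from compound 2 by 2-methoxyphenyl in place of 4-methoxyphenyl on a nitrogen on an aromatic ring. Among the compounds with values here, no measured step covers this rearrangement; the only comparable step, a 2.9-fold higher number from compound 1 to compound 2 (0.47 log units; beyond the scatter), was modest, so a step of similar size in either direction is expected, with a 1.4-fold higher number from compound 2 to compound 3 (0.13 log units; within the scatter) as the estimate. Compound 3 is estimated at 20000 nM, plausibly between 7000 nM and 60000 nM.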

Compound 3, half-maximal inhibitory concentration: 24200 nM
Compound 3: middle estimate off by 1.2-fold (0.08 log units), on the low side; measured number inside the range.
By their numbers in this assay, from the lowest: compound 1; then compounds 2 and 3 (each within the scatter of the next).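

In this assay, the 2-methoxyphenyl and 4-methoxyphenyl groups on this nitrogen cannot be told apart, since a 1.6-fold higher number from compound 2 to compound 3 (0.22 log units; within the scatter). So where the methoxy group sits on this ring makes no readable difference among these two compounds, while 3-chloro-4-fluorophenyl stays clearly apart from the 2-methoxyphenyl group as well, with a 4.8-fold higher number from compound 1 to compound 3 (0.68 log units; beyond the scatter). Nothing measured here explains these numbers. On these data alone, whether a phenyl ring carrying an amine or a carboxylic acid on this nitrogen would come closer to compound 1 remains open.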